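The source may hold more compounds than are shown below. What is called first, only, known or untested is meant among the compounds shown, and "the series" means these compounds.

Measured compounds:
- compound 1, `N#C/C(=C\c1c(-c2ccccc2)[nH]c2ccccc12)C(=O)c1ccccc1`: 7300 nM
- compound 2, `COc1ccc(-c2[nH]c3ccc(OC)cc3c2/C=C(\C#N)S(=O)(=O)c2ccccc2)cc1`: 1300 nM
- compound 3, `CC(=O)/C(=C\c1c(-c2ccccc2)[nH]c2ccccc12)S(=O)(=O)c1ccccc1`: 1400 nM

These three compounds were tested in a functional assay on CCRF-CEM cells (Homo sapiens) for inhibition, read by sulforhodamine B assay, with a stated time of 48 h; a higher number here means a weaker inhibitor of growth, a lower number a stronger inhibitor of growth. Compound 2 gives the lowest number of the three, but compound 3 sits so close that the two cannot be told apart within the usual scatter; only compound 1 stands clearly apart from compound 2, with the higher number. No pair of these compounds differs in just one place, so no single-point step has been measured here.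

Compound 4, `COc1ccc(-c2[nH]c3ccccc3c2/C=C(\C#N)S(=O)(=O)c2ccccc2)cc1`, has not yet been tested. It differs from compound 2 in one place: hydrogen in place of methoxy on an aromatic carbon. Among the measured compounds shown here, no measured pair shows what removing a methoxy at that place does on this shared core, so the expectation rests only on the closeness of compound 2 and compound 3 in this assay and on the small size of the change. The step from compound 2 to compound 4 is expected to be small, a 1.5-fold higher number from compound 2 to compound 4 (0.19 log units; within the scatter), likely not beyond the scatter, with a slight lean toward a higher number. Compound 4 is therefore estimated at 2000 nM, within a range from 800 nM to 5000 nM.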

Compound 4, concentration for 50% growth inhibition: 1300 nM
Beside the measured number, compound 4's estimate is 1.5-fold (0.19 log units) above it, within the range that was stated.
By their numbers in this assay, from the lowest: compounds 2, 4 and 3 (each within the scatter of the next); then compound 1.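

In this assay the first step measured in one place shows no change at the digits printed from compound 2 to compound 4 (within the scatter) when the methoxy is removed and hydrogen takes its place. On this aromatic carbon, on a ring that is part of a fused system, the methoxy can therefore go without a change that rises above the scatter, at least on this shared core. No measurement at hand gives a reason for this.

The compounds shown leave open whether a different group on the same carbon, such as an amine, a carboxylic acid or a longer chain, would move the number beyond the scatter. They also leave open whether the second methoxy, which compound 2 and compound 4 both carry, could be replaced by hydrogen just as freely.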